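The source may hold more compounds than are shown below. What is called first, only, known or untested is meant among the compounds shown, and "the series" means these compounds.

Compound 1 `CC(O)(CSc1ccccc1)c1nc(-c2ccccc2)no1` gives > 100000 nM in a functional assay on DU-145 cells (Homo sapiens) for cytotoxicity, read by MTT assay (a lower number here means a stronger inhibitor, a higher number a weaker inhibitor), which is a limit of the assay rather than a number.
Compound 2 `CC(O)(CSc1ccc(Br)cc1)c1nc(-c2ccccc2)no1` gives > 100000 nM, again a limit and not a number.
Compound 3 `CC(O)(CSc1ccc(Br)cc1)c1nc(-c2ccc(F)c(Cl)c2)no1` gives 8800 nM.

Compound 2 therefore stands only at the limit of > 100000 nM in this assay, at which 2 of the 3 values shown sit, with no measured number of its own. Compound 4 `CC(O)(CSc1ccc(F)cc1)c1nc(-c2ccccc2)no1` differs from compound 2 by fluoro in place of bromo on an aromatic carbon. Of the measured steps, only a step that the two limits leave unreadable from compound 1 to compound 2 concerns the same place, and both of its values sit at the limit, so it gives no size; an at least 11-fold lower number from compound 2 to compound 3 (1.05 log units; beyond the scatter) alters a different part of the structure. Among the measured compounds shown here, no measured step thus points in either direction, and compound 4 is expected to stay near the limit, with a step that the limit leaves unreadable from compound 2 to compound 4 as the expected step. Compound 4 is estimated at 150000 nM, with a range from 40000 nM to 600000 nM.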

Compound 4, half-maximal inhibitory concentration: > 100000 nM
Compound 4: only a limit was reported; the forecaster's own chance of this, stated with the estimate: 75%; the middle value lies beyond the limit too.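

Compound 4 gives > 100000 nM, a limit of the assay and not a number, so its steps from compound 1 and compound 2 cannot be read. On these data alone, whether hydrogen, bromo and fluoro at this place differ at all in this assay stays open.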